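Propoxy esters and plasma half-life in the rat

The compounds below may be only part of what the source reports. "The series", "measured", "known", "first", "only" and "open" are said of these compounds alone.

The account covers four diaryl ester compounds. Compound 1 `COC(=O)CCCC=C(c1cc(Cl)c(OC)c(C(=O)OC)c1)c1cc(Cl)c(OC)c(C(=O)OC)c1` and compound 3 `CCCOC(=O)CCCC=C(c1cc(Cl)c(OC)c(C(=O)OC)c1)c1cc(Cl)c(OC)c(C(=O)OC)c1` share one core, while compound 2 `COC(=O)CCCC=C(c1cc(C)c(OC)c(C(=O)OC)c1)c1cc(C)c(OC)c(C(=O)OC)c1` and compound 4 `CCCOC(=O)CCCC=C(c1cc(C)c(OC)c(C(=O)OC)c1)c1cc(C)c(OC)c(C(=O)OC)c1` share another; the difference between the two cores is not broken down here. In an ADME assay on the whole organism (plasma) for metabolic stability, with Rattus norvegicus as the target (on this read-out lower numbers stand for a shorter-lived compound and higher numbers for a longer-lived compound), compound 1 gives 0.0967 h, compound 3 gives 0.123 h and compound 2 gives 0.715 h. The change from compound 1 to compound 3 is ethyl in place of hydrogen on a saturated chain carbon bound to an oxygen next to a carbonyl group, and it made a step of a 1.3-fold higher number from compound 1 to compound 3 (0.10 log units; within the scatter). The same change, (ethyl in place of hydrogen on a saturated chain carbon bound to an oxygen next to a carbonyl group), leads from compound 2 to compound 4, which is not yet measured in this assay. Among the measured compounds shown here, since the step from compound 1 to compound 3 stayed within the scatter, the step from compound 2 to compound 4 in this assay is expected to be equally modest, about a 1.3-fold higher number from compound 2 to compound 4 (0.10 log units; within the scatter), resting on the single earlier pair. Compound 4 is therefore estimated to give 0.9 h in this assay, with a plausible range from 0.45 h to 1.8 h, the uncertainty coming mainly from the ordinary scatter of such measurements around the value of compound 2.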

Compound 4, half-life: 0.0867 h
Beside the measured number, compound 4's estimate is 10-fold (1.02 log units) above it, and the stated range ends above it.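

In this assay, the change from methoxycarbonyl to propoxycarbonyl gave an 8.2-fold lower number from compound 2 to compound 4 (0.92 log units; beyond the scatter), while on the core of compound 1 the same change stayed within the scatter. The change therefore did not carry over from one core to the other, and the earlier pair proved no guide to the later one: the same change on two cores in this assay, a 1.3-fold higher number (0.10 log units; within the scatter) from compound 1 to compound 3 and an 8.2-fold lower number (0.92 log units; beyond the scatter) from compound 2 to compound 4, 10-fold (1.02 log units) apart, beyond the scatter of two such steps

This shows that, in this series, the outcome of the change depends on the core it is made on, but it does not show which part of the core is responsible or why the two cores part, and one pair on each core cannot say how the change would behave on any further core.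

The compounds shown leave open whether ethoxycarbonyl or butoxycarbonyl in the same place would follow the drop seen on the core of compound 2. They also leave open how an amide or a carboxylic acid there would fare on either core.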